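The source may report more compounds than this note shows. Statements on the series, on what has been measured and on what is new or still open speak of the compounds shown alone.

Compound 1 `Cc1cccc(CNc2cc(C)nc3c(-c4ccccc4)c(C)nn23)n1`: < 5000 nM
Compound 2 `Cc1cc(NCc2ccccn2)n2ncc(-c3ccccc3F)c2n1`: 5000 nM

Within the data shown here, in a physicochemical assay for solubility, read by HPLC, using the shake flask method, measured as kinetic solubility, with a stated time of 2 h, at pH 7.4 (on this read-out lower numbers stand for lower solubility and higher numbers for higher solubility), compound 2 gives 5000 nM, and this is the only number in the set. Compound 1 returns a limit rather than a number, namely (the limit of < 5000 nM in this assay, at which 1 of the 2 values shown sits). Compound 3 `Cc1cc(NCc2ccccn2)n2ncc(C3=CCOCC3)c2n1` has not been measured in this assay. It differs from compound 2 in one place: a group of 6 heavy atoms (5 carbon, 1 oxygen; one six-membered non-aromatic ring with 1 hetero atom) in place of a group of 7 heavy atoms (6 carbon, 1 fluorine; one six-membered aromatic ring of carbon only), on an aromatic carbon. Among the measured compounds shown here, no step between two measured compounds is available to calibrate what this change does to solubility, so the expectation rests on the single number for compound 2 and on the change itself. Compound 3 is expected to show a rise in solubility of a 3.0-fold higher number from compound 2 to compound 3 (0.48 log units; beyond the scatter), a step beyond the usual scatter of the assay. The estimate for compound 3 is 15000 nM, with a range from 5000 nM to 50000 nM.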

Compound 3, solubility: 171000 nM
The estimate for compound 3 lay 11-fold (1.06 log units) below the measured number, outside the stated range (above it).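

In this assay, the aromatic carbon of the five-membered aromatic ring proves to be a place where one change moves the read-out strongly: putting the six-membered non-aromatic ring with its oxygen in place of 2-fluorophenyl gives a 34-fold higher number from compound 2 to compound 3 (1.53 log units; beyond the scatter) and lies well beyond the scatter. Among these compounds, this is the first step that can be read in the set, and it shows that the rest of compound 2 can stay untouched while this single group makes a large difference. The compounds shown offer no measured property that accounts for a step of this size.

This single pair cannot separate the part played by the ring oxygen from that of losing the aromatic ring or the fluorine. A plain phenyl, a saturated tetrahydropyran or a piperidine amine at this carbon would be needed to tell how far the effect depends on each feature.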